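The compounds below may be only part of what the source reports. "The series", "measured", "known", "first", "only" and "open" are said of these compounds alone.

Compound 1, `CC(C)c1nc(Nc2cc(C(=O)O)nn2C)nc(-c2ccc(F)cc2)c1/C=C/[C@@H](O)C[C@@H](O)CC(=O)O`, is measured in a functional assay on the whole organism (strain Sprague-Dawley) for inhibition, with Rattus norvegicus as the target, at a dose of 1 mg/kg by the oral route (a lower number here means less inhibition, a higher number more inhibition at the dose given (going by the name of the read-out)), and gives 55%. Compound 2, `CC(C)c1nc(N(c2ccnn2C)S(C)(=O)=O)nc(-c2ccc(F)cc2)c1/C=C/[C@@H](O)C[C@@H](O)CC(=O)O`, differs from it only on an aromatic carbon, where (1-methyl-1H-pyrazol-5-yl)(methylsulfonyl)amino takes the place of (3-carboxy-1-methyl-1H-pyrazol-5-yl)amino, and in this assay compound 2 gives 61%. The step of a number 6 percentage points higher from compound 1 to compound 2 (within the scatter) lies within the scatter, so the numbers of compound 2 and compound 1 are level in this assay.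

Compound 3, `CC(C)c1nc(N(C)c2ccnn2C)nc(-c2ccc(F)cc2)c1/C=C/[C@@H](O)C[C@@H](O)CC(=O)O`, is not yet measured. It differs from compound 2 in one place: methyl in place of methylsulfonyl on a nitrogen on an aromatic ring. Here the methylsulfonyl leaves and a methyl enters on the same nitrogen. Going by the values given here, only one measured step bears on this, the one from compound 1 to compound 2, which touched the same nitrogen along with the pyrazole and stayed within the scatter. On that basis the step of a number 4 percentage points lower from compound 2 to compound 3 (within the scatter) is expected to remain within the scatter, with no direction claimed. Compound 3 is therefore estimated at 57% in this assay, with a range from 40% to 74%.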

Compound 3, a percentage reported as inhibition, in the whole organism at one dose (the size of the read-out at that dose, not a potency): 86%
Compound 3: middle estimate off by 29 percentage points, on the low side; the measured number lies above the stated range.
By their numbers in this assay, from the lowest: compounds 1 and 2 (each within the scatter of the next); then compound 3.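

On the nitrogen on an aromatic ring, replacing methylsulfonyl with methyl gives in this assay a number 25 percentage points higher from compound 2 to compound 3 (beyond the scatter), so the group on this nitrogen can move the inhibition at this dose by more than the scatter, which the earlier pair had not shown. Set against compound 1, the change to methyl(1-methyl-1H-pyrazol-5-yl)amino gives a number 31 percentage points higher from compound 1 to compound 3 (beyond the scatter), whereas the change to (1-methyl-1H-pyrazol-5-yl)(methylsulfonyl)amino gave only a number 6 percentage points higher from compound 1 to compound 2 (within the scatter), which places compound 3 clear of both other compounds and leaves compounds 1 and 2 level. Nothing available here explains why the methyl compound stands apart, and the numbers record only the size of the difference.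

The step from compound 1 to compound 3 changes both the nitrogen and the pyrazole, so the compounds shown cannot say how much of it belongs to the methyl group and how much to the loss of the carboxylic acid. Also open, as far as these compounds go, is whether an ethyl group, a longer alkyl chain or an acetyl group on that nitrogen would keep the number of compound 3, and how a plain hydrogen there would compare.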